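The source may hold more compounds than are shown below. What is called first, only, known or untested is meant among the compounds shown, and "the series" means these compounds.

Of the compounds shown here, three sharing one core have been tested in a functional assay on M21 cells (Homo sapiens) for antiproliferative activity, read by sulforhodamine B assay, with a stated time of 48 h; a lower number here means a stronger inhibitor, a higher number a weaker inhibitor: compound 1 (`COc1ccc(OS(=O)(=O)c2ccc(N3CCN(C)C3=O)cc2)cc1`), compound 2 (`CCCCN1CCN(c2ccc(S(=O)(=O)Oc3ccc(OC)c(OC)c3)cc2)C1=O`) and compound 3 (`CCCCN1CCN(c2ccc(S(=O)(=O)Oc3cc(Br)cc(Br)c3)cc2)C1=O`). Compound 1 gives > 100000 nM, which is a limit of the assay and not a number. Compound 2 gives > 100000 nM, also a limit. Compound 3 gives > 100000 nM, again a limit, so it has no number of its own and stands level with the other two as far as can be told. The whole record so far is the limit of > 100000 nM in this assay, at which 3 of the 3 values shown sit.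

Compound 4 (`CCCCN1CCN(c2ccc(S(=O)(=O)Oc3ccc(OC)cc3)cc2)C1=O`) is still unmeasured. Its difference from compound 3 is 4-methoxyphenyl in place of 3,5-dibromophenyl on an oxygen. Among the compounds with values here, the one measured step at this place is a step that the two limits leave unreadable from compound 2 to compound 3, so it offers no size to carry over. Compound 1 also carries the 4-methoxyphenyl group, on a core with a methyl in place of the butyl chain, and its result is the limit > 100000 nM. With nothing measured to suggest a shift, the expected step is a number no higher from compound 3 to compound 4 (the limit leaves the size open), with no direction beyond the scatter. For compound 4 the estimate is 100000 nM, with an expected range from 30000 nM to 150000 nM, and another reading at the limit is the likeliest outcome.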

Compound 4, half-maximal inhibitory concentration: > 100000 nM
Compound 4 was reported as a limit (the forecaster's own chance of this, stated with the estimate: 80%); the middle value sits exactly at the limit.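

Compound 4 comes out as a limit and not a number, just like compound 1, compound 2 and compound 3, so no step among these compounds can be read: the limit of > 100000 nM in this assay, at which 4 of the 4 values shown sit.

The compounds shown leave open how far each one lies beyond that limit in this assay, and whether any group on the oxygen gives a readable value.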